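The source may report more compounds than this note shows. Statements on the series, on what has been measured and on what is new or still open speak of the compounds shown alone.

Measured compounds:
compound 1, `COc1ccccc1S(=O)(=O)/C=C/c1cccnc1`, giving 92%
compound 2, `COc1ccccc1S(=O)(=O)/C=C/c1ccncc1`, giving 78.9%

Both numbers come from an ADME assay on BV-2 cells (Mus musculus) for cytotoxicity, with a stated time of 24 h, tested at 50 uM; a higher number here means a weaker effect of the compound at the concentration tested, a lower number a stronger effect. Compound 2 holds the lower of the two, and its nearest neighbour is compound 1, whose value lies above it by a number 13.1 percentage points lower from compound 1 to compound 2 (beyond the scatter). Within the data shown here, the step from compound 1 to compound 2 is the only change measured so far, and it swaps one ring attachment for another of the same size.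

Compound 3, `COc1ccccc1S(=O)(=O)/C=C/c1cncnc1`, has not yet been measured. It differs from compound 2 in one place: pyrimidin-5-yl in place of pyridin-4-yl on a double-bonded chain carbon bound to a double-bonded chain carbon. This change again keeps a six-membered aromatic ring on the same chain carbon, but the measured step gives no direct guide to adding a second ring nitrogen. With a single step to draw on, and that step being of modest size, a change of similar or smaller size is expected in this assay, with no clear direction. For compound 3 the estimate is 80%, within 62% to 96%, which means an expected step of a number 1.1 percentage points higher from compound 2 to compound 3 (within the scatter) that stays within the scatter.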

Compound 3, a percentage reported as activity, at one concentration (the size of the read-out at that concentration, not a potency): 97.9%
Compound 3: middle estimate off by 17.9 percentage points, on the low side; measured number outside the range, above it.
By their numbers in this assay, from the lowest: compound 2; then compounds 1 and 3 (each within the scatter of the next).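

In this assay, pyrimidin-5-yl in place of pyridin-4-yl gives a number 19 percentage points higher from compound 2 to compound 3 (beyond the scatter), which shows that the lower number of compound 2 is not shared by every six-membered aromatic ring on this chain carbon. Pyrimidin-5-yl in place of pyridin-3-yl gives a number 5.9 percentage points higher from compound 1 to compound 3 (within the scatter), so these two rings cannot be told apart here, and among the three compounds only compound 2, with pyridin-4-yl, stands apart from the others, showing the stronger effect at the concentration tested. No supporting measurement is available to explain why the pyridin-4-yl compound behaves differently from the other two.

Going by these compounds, all three compounds share the same core and differ only in the ring on this chain carbon, so it remains open what a plain phenyl ring, or a pyridine ring carrying an amine or a carboxylic acid, would give at this place. Each number is also a reading at a single concentration, which leaves open whether compound 2 would still stand apart from compound 1 and compound 3 at other concentrations.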